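The source may hold more compounds than are shown below. What is called first, only, known or untested is meant among the compounds shown, and "the series" means these compounds.

Compounds measured so far:

compound 1 `O=C1CS/C(=N\c2csc(-c3ccc(Cl)cc3)c2)N1` — > 50000 nM (a limit)
compound 2 `COc1ccc(/C=C2\S/C(=N\c3csc(-c4ccc(Cl)cc4)c3)NC2=O)cc1` — 1300 nM
compound 3 `Cc1ccc(/C=C2\S/C(=N\c3csc(-c4ccc(Cl)cc4)c3)NC2=O)cc1` — 1000 nM

All three share one core, seen in full in compound 1. In a functional assay on HCT-116 cells (Homo sapiens) for cytotoxicity, read by MTT assay, with a stated time of 72 h (on this read-out higher numbers stand for weaker inhibition and lower numbers for stronger inhibition), compound 1 reaches only the assay limit, (the limit of > 50000 nM in this assay, at which 1 of the 3 values shown sits). Compound 2 and compound 3 each carry an extra six-membered aromatic ring joined to that core through a double bond, and both give numbers. The step of a 1.3-fold lower number from compound 2 to compound 3 (0.11 log units; within the scatter) is a small one. Compound 3 therefore holds the lower of the two numbers, but its gap to compound 2 lies within the usual scatter, so the two cannot be ranked against each other.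

Compound 4 `O=C1N/C(=N/c2csc(-c3ccc(Cl)cc3)c2)S/C1=C\c1ccc(Br)cc1` changes only the group on that outer ring: bromo in place of methyl on an aromatic carbon. Within the data shown here, the one measured step that resembles it, a swap of one small para group for another, is a 1.3-fold lower number from compound 2 to compound 3 (0.11 log units; within the scatter), which stayed within the scatter. Bromo is a different kind of group from methyl or methoxy, so the expectation rests on slender evidence, but nothing measured points to a large move either way. The estimated step of a 1.1-fold lower number from compound 3 to compound 4 (0.05 log units; within the scatter) is expected to be small. Compound 4 is therefore estimated at 900 nM, with a likely span from 300 nM to 2700 nM.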

Compound 4, half-maximal inhibitory concentration: 3300 nM
Beside the measured number, compound 4's estimate is 3.7-fold (0.56 log units) below it; measured number outside the range, above it.
By their numbers in this assay, from the lowest: compounds 3 and 2 (each within the scatter of the next); then compound 4. At a limit, above all of these: compound 1.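

In this assay, this place on the outer ring, para to a large group, now proves sensitive to the group it carries: a 3.3-fold higher number from compound 3 to compound 4 (0.52 log units; beyond the scatter) lies beyond the scatter, and so does a 2.5-fold higher number from compound 2 to compound 4 (0.40 log units; beyond the scatter). Methyl and methoxy had given numbers within the scatter of each other, so the earlier pair suggested that one small group could stand in for another here, and the change from 4-methylphenyl to 4-bromophenyl shows that this does not hold for every group. Both new steps are modest, and nothing available here bears on why bromo separates from the other two.

Among these compounds, with only three groups seen at this place, it stays open whether a fluoro, an amine or a carboxylic acid would sit with methyl and methoxy or would go the way of bromo. It is also open whether bromo would give a similar number on a different carbon of the same ring, since every outer ring shown carries its group at this one place.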